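The source may hold more compounds than are shown below. What is called first, only, known or untested is meant among the compounds shown, and "the series" means these compounds.

Series notes, chain length at the saturated ring carbon.

Compound 1 `CCCCC1Nc2ccccc2C(=O)N1Cc1ccc(-c2ccccc2-c2nn[nH]n2)cc1` gives in a functional assay on the whole organism for inhibition, with Rattus norvegicus as the target, at a dose of 15 mg/kg by the intravenous route (on this read-out higher numbers stand for more inhibition at the one dose given (going by the name of the read-out) and lower numbers for less inhibition), a read-out of 88%. Compound 2 `CCCCC1N(Cc2ccc(-c3ccccc3-c3nn[nH]n3)cc2)C(=O)c2ccccc2N1C` carries methyl in place of hydrogen on a nitrogen on an aromatic ring in a ring, and in this assay compound 2 gives 88%. The step of no change at the digits printed from compound 1 to compound 2 (within the scatter) therefore leaves compound 2 level with compound 1 at the digits shown, within the scatter; these two values are the whole of the measured series so far.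

Compound 3 `CCCC1N(Cc2ccc(-c3ccccc3-c3nn[nH]n3)cc2)C(=O)c2ccccc2N1C` is the next member. It differs from compound 2 by hydrogen in place of methyl on a saturated chain carbon, three bonds along the chain from a saturated ring carbon; cut one bond further out, the same change reads butyl to propyl. No measured step touches this chain: the one step available, from compound 1 to compound 2, sits on a ring nitrogen and gave no change at the digits shown, so it offers no direct guide to shortening the chain. With nothing to argue for a move in either direction, the expectation for compound 3 in this assay is a step of about a number 6 percentage points lower from compound 2 to compound 3 (within the scatter), that is, no change beyond the scatter. The estimate for compound 3 in this assay is 82%, expected to lie between 62% and 95%.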

Compound 3, a percentage reported as inhibition, in the whole organism at one dose (the size of the read-out at that dose, not a potency): 88%
The estimate for compound 3 lay 6 percentage points below the measured number; the measured number falls inside the stated range.
By their numbers in this assay, from the lowest: compounds 1, 2 and 3 (each within the scatter of the next).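

In this assay, for the compounds shown here, the series now has a first reading on the chain itself: hydrogen in place of methyl on a saturated chain carbon, three bonds along the chain from a saturated ring carbon, the same change as butyl to propyl, gives no change at the digits printed from compound 2 to compound 3 (within the scatter) with the methyl kept on the ring nitrogen. The earlier step spoke only to that ring nitrogen, whereas this one shows that, at this one dose, the read-out does not separate butyl from propyl on the core of compound 2. The compounds shown come with no measurement that could account for this level result.

From the compounds shown here alone, whether the same holds much further from these two chain lengths stays open: an ethyl, a pentyl or longer chain, a branched chain such as isobutyl, or a chain ending in an amine or a carboxylic acid could each read differently. Also open, going by these compounds, is whether propyl behaves the same with hydrogen on the ring nitrogen, as in compound 1, and, since the read-out gives the size of the effect at one dose and not a potency, whether these compounds would stay level at other doses.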